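The source may report more compounds than this note shows. Statements on the series, on what has been measured and on what is new or still open speak of the compounds shown alone.

Measured so far in a physicochemical assay for lipophilicity, in phosphate buffer, measured as octanol-water partition; on this read-out higher numbers stand for higher lipophilicity and lower numbers for lower lipophilicity:
compound 1 `Cc1cccc(NC(=S)NC(=O)Nc2ccc3c(c2)C(=O)C(=O)N3Cc2ccccc2)c1` gives 2.92
compound 2 `COc1ccccc1NC(=S)NC(=O)Nc1ccc2c(c1)C(=O)C(=O)N2Cc1ccccc1` gives 2.38
compound 3 `Cc1cccc(NC(=S)NC(=O)Nc2ccc3c(c2)C(=O)C(=O)N3Cc2ccccc2Cl)c1` gives 3.72

Compound 3 stands highest of the three in this assay; its nearest neighbour is compound 1, and compound 2 lies furthest below it. Compound 4 `COc1ccc(NC(=S)NC(=O)Nc2ccc3c(c2)C(=O)C(=O)N3Cc2ccccc2Cl)cc1` differs from compound 3 in one place: 4-methoxyphenyl in place of 3-methylphenyl on an amide-type nitrogen. Within the data shown here, one measured step bears on this, the exchange of the same 3-methylphenyl for a methoxyphenyl on the same nitrogen, which gave a number 0.54 log units lower from compound 1 to compound 2 (beyond the scatter). The other step, a number 0.80 log units higher from compound 1 to compound 3 (beyond the scatter), concerns a different position and has already been carried into compound 3. A lowering of similar size is therefore expected, that is a number 0.52 log units lower from compound 3 to compound 4 (beyond the scatter). Compound 4 is estimated at 3.2, within a range of 2.8 to 3.6.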

Compound 4, partition coefficient: 3.24
Beside the measured number, compound 4's estimate is 0.04 log units below it; measured number inside the range.
By their numbers in this assay, from the lowest: compound 2; then compound 1; then compound 4; then compound 3.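

In this assay, the exchange of 3-methylphenyl for 4-methoxyphenyl on this amide-type nitrogen gives a number 0.48 log units lower from compound 3 to compound 4 (beyond the scatter). The earlier step, a number 0.54 log units lower from compound 1 to compound 2 (beyond the scatter), was seen with 2-methoxyphenyl and without the chloro; the lowering therefore recurs with a different methoxyphenyl and with the chloro present. Two exchanges at this nitrogen now point the same way, though each starts from a different compound.

Going by these compounds, how 4-methoxyphenyl behaves without the chloro stays open, as does the effect of an aminophenyl or carboxyphenyl group at this nitrogen. No measurement shown accounts for the lowering.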